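The compounds below may be only part of what the source reports. "The series", "measured", "known", "first", "only" and "open" are said of these compounds alone.

Measured so far in an ADME assay on cells (Hepatocyte, Mus musculus) for metabolic stability, with a stated time of 30 min; a higher number here means that more of the compound is left, a lower number that less of the compound is left:
compound 1 `NC1CCC(CN2CCN(c3cc(=O)c4cc(C(F)(F)F)cc([N+](=O)[O-])c4s3)CC2)CC1` gives 107%
compound 2 `CS(=O)(=O)NC1CCC(CN2CCN(c3cc(=O)c4cc(C(F)(F)F)cc([N+](=O)[O-])c4s3)CC2)CC1` gives 111%
compound 3 `O=C(OC1CCC(CN2CCN(c3cc(=O)c4cc(C(F)(F)F)cc([N+](=O)[O-])c4s3)CC2)CC1)c1cccs1` gives 1.8%

Compound 2 holds the highest of the three numbers in this assay, but its nearest neighbour is compound 1 with a number 4 percentage points higher from compound 1 to compound 2 (within the scatter), so the two cannot be ordered. Compound 3 is far off from both: a number 105.2 percentage points lower from compound 1 to compound 3 (beyond the scatter) and a number 109.2 percentage points lower from compound 2 to compound 3 (beyond the scatter).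

The unmeasured compound 4 `O=c1cc(N2CCN(CC3CCC(NS(=O)(=O)c4ccccc4)CC3)CC2)sc2c([N+](=O)[O-])cc(C(F)(F)F)cc12` departs from compound 2 by phenyl in place of methyl on a sulfonyl sulfur.

Among the compounds with values here, only one measured step touches the same part of the molecule: a number 4 percentage points higher from compound 1 to compound 2 (within the scatter), which added the methylsulfonyl on the amine nitrogen without moving the number beyond the scatter. The two large steps, a number 105.2 percentage points lower from compound 1 to compound 3 (beyond the scatter) and a number 109.2 percentage points lower from compound 2 to compound 3 (beyond the scatter), concern a different exchange, the ((thiophen-2-yl)carbonyl)oxy in place of amino or methanesulfonamido on the saturated ring carbon, and do not speak directly to the methyl-to-phenyl change on the sulfonyl sulfur. Within the data shown here, no step involving a phenyl is available. The expectation for compound 4 is therefore a small step, if any, in this assay, most likely within the scatter, with a slight lean downward allowed for the larger group.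

Compound 4 is estimated at 92% in this assay, between 60% and 112%, an expected step of a number 19 percentage points lower from compound 2 to compound 4 (beyond the scatter).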

Compound 4, percent of the compound remaining: 95.3%
Compound 4: middle estimate off by 3.3 percentage points, on the low side; the range from low to high includes it.
By their numbers in this assay, from the lowest: compound 3; then compound 4; then compounds 1 and 2 (each within the scatter of the next).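

In this assay, the sulfonyl sulfur proves to be a position where the group matters: phenyl in place of methyl gives a number 15.7 percentage points lower from compound 2 to compound 4 (beyond the scatter) and the phenylsulfonyl on the amine nitrogen gives a number 11.7 percentage points lower from compound 1 to compound 4 (beyond the scatter) whereas the methylsulfonyl on that nitrogen gave only a number 4 percentage points higher from compound 1 to compound 2 (within the scatter) in the earlier set. The loss stays modest beside a number 93.5 percentage points higher from compound 3 to compound 4 (beyond the scatter) so a sulfonamide carrying an aromatic ring remains far from the collapse seen with the ester of compound 3, and an aromatic ring alone does not bring that collapse in this series. Nothing available explains either shift.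

From the compounds shown here alone, whether the drop belongs to the phenyl ring as such or would also follow an ethyl or longer alkyl chain on the sulfonyl sulfur remains open, as does the effect of a fluoro or methoxy group on the phenyl ring. A thiophene-2-sulfonyl group or a thiophene-2-carboxamide on the amine nitrogen would separate the contribution of the thiophene ring from that of the ester oxygen in compound 3.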